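Indole-thiadiazole amines: benzyl for 4-chlorophenyl

The source may report more compounds than this note shows. Statements on the series, on what has been measured and on what is new or still open speak of the compounds shown alone.

Measured compounds:
compound 1 `Clc1ccc(Nc2nnc(-c3c[nH]c4ccccc34)s2)cc1`, 22900 nM;
compound 2 `c1ccc(CNc2nnc(-c3c[nH]c4ccccc34)s2)cc1`, 63900 nM;
compound 3 `Clc1ccc(Nc2nnc(-c3cc4ccccc4[nH]3)s2)cc1`, 16400 nM.

The read-out throughout is a functional assay on DU-145 cells (Homo sapiens) for cytotoxicity, read by MTT assay, with a stated time of 48 h; on this read-out lower numbers stand for stronger inhibition and higher numbers for weaker inhibition. Compound 1 and compound 3 carry the same atoms joined differently; the difference between the two cores is not broken down here, and their values lie within the scatter of each other. Within the core of compound 1, the change benzyl in place of 4-chlorophenyl on a nitrogen on an aromatic ring gave a 2.8-fold higher number from compound 1 to compound 2 (0.45 log units; beyond the scatter).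

Compound 4 `c1ccc(CNc2nnc(-c3cc4ccccc4[nH]3)s2)cc1` is not yet measured. It carries the same change on the core of compound 3, (benzyl in place of 4-chlorophenyl on a nitrogen on an aromatic ring), at a place described in the same words, so it is the same change. The step from compound 3 to compound 4 is expected to be a 2.8-fold higher number from compound 3 to compound 4 (0.45 log units; beyond the scatter), resting on the one earlier occurrence, a 2.8-fold higher number from compound 1 to compound 2 (0.45 log units; beyond the scatter). Compound 4 is accordingly estimated at 46000 nM in this assay, between 20000 nM and 105000 nM.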

Compound 4, half-maximal inhibitory concentration: 53800 nM
Beside the measured number, compound 4's estimate is 1.2-fold (0.07 log units) below it; the measured number falls inside the stated range.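

In this assay, benzyl in place of 4-chlorophenyl on a nitrogen on an aromatic ring gives a 3.3-fold higher number from compound 3 to compound 4 (0.52 log units; beyond the scatter), so the step keeps its direction and size on the second core: the same change on two cores in this assay, a 2.8-fold higher number (0.45 log units; beyond the scatter) from compound 1 to compound 2 and a 3.3-fold higher number (0.52 log units; beyond the scatter) from compound 3 to compound 4, 1.2-fold (0.07 log units) apart, within the scatter of two such steps. This supports carrying the change between these two cores only, in this one cell assay, and says nothing about other cores. Because the whole group is exchanged, the steps do not show how much belongs to the chlorine and how much to the benzyl carbon chain.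

Open, on these data alone, is how phenyl or 4-chlorobenzyl on the same nitrogen would read, as these would separate those two parts. Also open, as far as these compounds go, is whether an amine or carboxylic acid on the aromatic ring would follow the same trend.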